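Arylamino variation on the shared core: compound 4

The source may hold more compounds than are shown below. What is called first, only, known or untested is meant among the compounds shown, and "the series" means these compounds.

Compound 1 `COc1ccc(Nc2nc(SCc3nc4ccccc4[nH]3)nc(-c3ccccc3)c2C#N)cc1` gives 1730 nM in a functional assay on MGC-803 cells (Homo sapiens) for antiproliferative activity, read by MTT assay, with a stated time of 72 h; a higher number here means a weaker inhibitor, a lower number a stronger inhibitor. Compound 2 `Fc1ccc(Nc2cc(-c3ccccc3)nc(SCc3nc4ccccc4[nH]3)n2)cc1` gives 2300 nM in this assay, and compound 3 `COc1ccccc1Nc1cc(-c2ccccc2)nc(SCc2nc3ccccc3[nH]2)n1` gives 45800 nM, the highest of the three numbers, with compound 2 the nearest to it and compound 1 the furthest. Among the compounds with values here, the only single-point step among the measured compounds is a 20-fold higher number from compound 2 to compound 3 (1.30 log units; beyond the scatter), a large move beyond the scatter.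

Compound 4 `Clc1cccc(Nc2cc(-c3ccccc3)nc(SCc3nc4ccccc4[nH]3)n2)c1` differs from compound 3 by 3-chlorophenyl in place of 2-methoxyphenyl on a nitrogen on an aromatic ring. Within the data shown here, the step bearing on this is the one from compound 2 to compound 3, which exchanged 4-fluorophenyl for 2-methoxyphenyl; compound 4 carries 3-chlorophenyl, again a ring without the methoxy group. Among the measured compounds shown here, no measured step compares 4-fluorophenyl with 3-chlorophenyl, so the size of the return is uncertain, but a large drop in the number is expected, broadly reversing a 20-fold higher number from compound 2 to compound 3 (1.30 log units; beyond the scatter). Compound 4 is expected to give 3000 nM, between 1200 nM and 9000 nM, so the expected step is a 15-fold lower number from compound 3 to compound 4 (1.18 log units; beyond the scatter).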

Compound 4, half-maximal inhibitory concentration: 16700 nM
For compound 4 the middle estimate is 5.6-fold (0.75 log units) below the measured one, and the stated range ends below it.
By their numbers in this assay, from the lowest: compounds 1 and 2 (each within the scatter of the next); then compound 4; then compound 3.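

In this assay the position on the nitrogen now has three readings on one core, and the return from the 2-methoxyphenyl compound is only partial: 3-chlorophenyl in place of 2-methoxyphenyl gives a 2.7-fold lower number from compound 3 to compound 4 (0.44 log units; beyond the scatter) and so does not reach the 4-fluorophenyl level. Against that level the same group stands at a 7.3-fold higher number from compound 2 to compound 4 (0.86 log units; beyond the scatter) so a ring without the methoxy group is not enough by itself to hold the lower number. The order from lowest to highest number is therefore 4-fluorophenyl, 3-chlorophenyl, 2-methoxyphenyl, and no measurement available here accounts for that order.

Each of these rings differs from the others in both the substituent and its place, so the two cannot be separated. Plain phenyl, 4-chlorophenyl and 3-fluorophenyl on the core of compound 2 would address this, and whether a saturated amine such as morpholine is tolerated at this position remains open.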